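Adding a Second Fluoro to the Chromane Core

The source may report more compounds than this note shows. Statements on the series, on what has been measured and on what is new or still open speak of the compounds shown alone.

The three measured compounds share one core and differ only in fluoro substitution on the aromatic ring. Compound 1 `CCCc1cnc(N2CCC(C3Cc4cc(C5=CCN(S(=O)(=O)CCC)CC5)ccc4O3)CC2)nc1` carries no fluoro there, and in a functional assay on HEK293 cells with Glucose-dependent insulinotropic receptor (Homo sapiens) as the target, read by cAMP accumulation, with a stated time of 60 min (on this read-out higher numbers stand for larger maximal responses and lower numbers for smaller maximal responses), compound 1 gives 107%. Compound 2 `CCCc1cnc(N2CCC(C3Cc4c(ccc(C5=CCN(S(=O)(=O)CCC)CC5)c4F)O3)CC2)nc1` has one fluoro, and in this assay compound 2 gives 123%. Compound 3 `CCCc1cnc(N2CCC(C3Cc4cc(C5=CCN(S(=O)(=O)CCC)CC5)cc(F)c4O3)CC2)nc1` has a fluoro at a different place, and in this assay compound 3 gives 93%, the lowest of the three values: compound 1 lies a number 14 percentage points lower from compound 1 to compound 3 (beyond the scatter) away, and compound 2 higher still.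

Compound 4 `CCCc1cnc(N2CCC(C3Cc4c(F)c(C5=CCN(S(=O)(=O)CCC)CC5)cc(F)c4O3)CC2)nc1` is the unmeasured member. It differs from compound 3 by fluoro in place of hydrogen on an aromatic carbon. The entering fluoro stands where compound 2 carries its fluoro, so compound 4 combines the fluoro of compound 2 with that of compound 3.

Among the compounds with values here, two steps bear on this change. The step of a number 16 percentage points higher from compound 1 to compound 2 (beyond the scatter) shows a modest rise when that fluoro enters, while a number 14 percentage points lower from compound 1 to compound 3 (beyond the scatter) shows a modest fall for the other fluoro. If the two fluoro groups act as they did on their own, a rise of about the size seen from compound 1 to compound 2 is expected, so for compound 4 a step of a number 15 percentage points higher from compound 3 to compound 4 (beyond the scatter) is estimated. Compound 4 is therefore expected to give 108%, within 94% to 124%.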

Compound 4, largest response reached (Emax), in percent of the reference or control that the assay uses: 119%
For compound 4 the middle estimate is 11 percentage points below the measured one; the range from low to high includes it.
By their numbers in this assay, from the lowest: compound 3; then compound 1; then compounds 4 and 2 (each within the scatter of the next).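

In this assay the entering fluoro, para to a fluoro group, raises the maximal response on a core that already carries a fluoro, with a number 26 percentage points higher from compound 3 to compound 4 (beyond the scatter), and this rise agrees with the one seen on the core of compound 1: the same change on two cores in this assay, a number 16 percentage points higher (beyond the scatter) from compound 1 to compound 2 and a number 26 percentage points higher (beyond the scatter) from compound 3 to compound 4, 10 percentage points apart, within the scatter of two such steps. The other fluoro, which had brought a fall on the core of compound 1, gives no step beyond the scatter once the first fluoro is present, with a number 4 percentage points lower from compound 2 to compound 4 (within the scatter), although the two steps for this fluoro also stay within the scatter of each other: the same change on two cores in this assay, a number 14 percentage points lower (beyond the scatter) from compound 1 to compound 3 and a number 4 percentage points lower (within the scatter) from compound 2 to compound 4, 10 percentage points apart, within the scatter of two such steps. Across these four compounds, none of which goes against it, the two fluoro groups therefore behave as largely independent changes, and the second fluoro leaves the gain from the first in place.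

The compounds shown leave open whether a chloro, a methyl or a methoxy group on this aromatic carbon would act as fluoro does here. They also leave open whether the same steps would hold if an amine or a carboxylic acid stood on the aromatic ring in place of the other fluoro.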